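Working notes: compound 3 to compound 4

The source may hold more compounds than are shown below. What is called first, only, known or untested is meant among the compounds shown, and "the series" means these compounds.

Measured in a functional assay with Homo sapiens as the target (on this read-out lower numbers stand for stronger inhibition and higher numbers for weaker inhibition), so far:
- compound 1 `CC(C)[C@H](NC(=O)COc1cccc2ccccc12)C(=O)N[C@@H](CC(=O)O)C(=O)COc1ccc(-c2ccccc2)cc1` gives 38700 nM in this read-out
- compound 2 `CC(C)[C@H](NC(=O)COc1cccc2ccccc12)C(=O)N[C@@H](CC(=O)O)C(=O)COc1ccccc1C(F)(F)F` gives 17300 nM in this read-out
- compound 3 `CC(C)[C@H](NC(=O)COc1cccc2ccccc12)C(=O)N[C@@H](CC(=O)O)C(=O)COc1ccccc1F` gives 15700 nM in this read-out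

Compound 3 sits at the low end of the three numbers together with compound 2, since a 1.1-fold lower number from compound 2 to compound 3 (0.04 log units; within the scatter) sets no order between them. The clear gap is to compound 1, with a 2.5-fold lower number from compound 1 to compound 3 (0.39 log units; beyond the scatter) on record.

Compound 4 `CC(C)[C@H](NC(=O)COc1cccc2ccccc12)C(=O)N[C@@H](CC(=O)O)C(=O)COc1ccc(F)c(F)c1` alters one group of compound 3, with 3,4-difluorophenyl in place of 2-fluorophenyl on an oxygen on a saturated carbon as the counted difference, that is, 3,4-difluorophenyl in place of 2-fluorophenyl on an oxygen on a saturated carbon.

All measured steps fall at this same place. Leaving 4-phenylphenyl gave modest changes, a 2.2-fold lower number from compound 1 to compound 2 (0.35 log units; beyond the scatter) and a 2.5-fold lower number from compound 1 to compound 3 (0.39 log units; beyond the scatter) being the two cases, while the exchange among the fluorine-bearing phenyl groups, a 1.1-fold lower number from compound 2 to compound 3 (0.04 log units; within the scatter) again, stayed within the scatter. Going by the values given here, no measured compound carries 3,4-difluorophenyl. In this assay no step beyond the scatter is therefore expected, in either direction. The estimated step is a 1.1-fold higher number from compound 3 to compound 4 (0.03 log units; within the scatter) on present evidence. For compound 4 the expected value is 17000 nM with an estimated range of 8000 nM to 36000 nM on present evidence.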

Compound 4, half-maximal inhibitory concentration: 16200 nM
The estimate for compound 4 lay 1.0-fold (0.02 log units) above the measured number; the range from low to high includes it.
By their numbers in this assay, from the lowest: compounds 3, 4 and 2 (each within the scatter of the next); then compound 1.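

In this assay there is a 1.0-fold higher number from compound 3 to compound 4 (0.01 log units; within the scatter) and also a 1.1-fold lower number from compound 2 to compound 4 (0.03 log units; within the scatter) so 3,4-difluorophenyl joins 2-fluorophenyl and 2-(trifluoromethyl)phenyl as a third fluorine-bearing phenyl group on this oxygen, with no order among the three. Going by these compounds alone, there is also a 2.4-fold lower number from compound 1 to compound 4 (0.38 log units; beyond the scatter) and with that step compound 1 remains the only compound set apart, now from all three others, while a change in the number of fluorines and in where they sit on the phenyl ring leaves the number within the scatter. No measurement on hand accounts for these results.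

On these data alone, whether an unsubstituted phenyl, or a phenyl carrying an amine or a carboxylic acid, would stay with compounds 2, 3 and 4 remains open. All four compounds share the rest of the core, so these steps say nothing about changes elsewhere in it, such as a longer chain in place of the naphthyloxy-free part of the acyl group.

Correction to the last sentence: All four compounds share the rest of the core, so these steps say nothing about changes elsewhere in it.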